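From Compound 1 to Compound 4: Changing the Amide Aryl Group

The compounds below may be only part of what the source reports. "The series", "measured", "known", "first", "only" and "open" are said of these compounds alone.

Within the data shown here, compound 1 `O=C(NCc1cccc(Cn2cnc3ccccc32)c1)c1cc(Br)c[nH]1` gives 16 nM in an assay for inhibition of Indoleamine 2,3-dioxygenase 1 (Homo sapiens), read by HPLC, with a stated time of 48 h (on this read-out higher numbers stand for weaker inhibition and lower numbers for stronger inhibition), the lowest of the three numbers measured so far. Compound 2 `O=C(NCc1cccc(Cn2cnc3ccccc32)c1)c1cc2ccccc2o1` gives 413 nM and compound 3 `O=C(NCc1cccc(Cn2cnc3ccccc32)c1)c1nc2ccccc2[nH]1` gives 407 nM in this assay. Both sit well above compound 1: a 26-fold higher number from compound 1 to compound 2 (1.41 log units; beyond the scatter) and a 25-fold higher number from compound 1 to compound 3 (1.41 log units; beyond the scatter), whereas a 1.0-fold lower number from compound 2 to compound 3 (0.01 log units; within the scatter).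

Compound 4 `O=C(NCc1cccc(Cn2cnc3ccccc32)c1)c1ccc(Br)cc1` has not yet been measured. It differs from compound 1 in a single place: 4-bromophenyl in place of 4-bromo-1H-pyrrol-2-yl on a carbonyl carbon. The two measured steps away from compound 1 bear on this change, since each likewise removes the 4-bromo-1H-pyrrol-2-yl group from the carbonyl carbon, and each cost a large and nearly equal amount. Compound 3 kept a hydrogen-bond donor yet lost as much as compound 2, so the presence of a donor alone did not keep the number low. Among the measured compounds shown here, compound 4 differs from both of those in keeping the bromine and in bringing a six-membered aromatic ring of carbon only, for which no measured precedent exists. The expectation is therefore a clearly weaker number, though perhaps a smaller step than the two already seen: a 9.4-fold higher number from compound 1 to compound 4 (0.97 log units; beyond the scatter). The estimate for compound 4 in this assay is 150 nM, with a range from 40 nM to 600 nM.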

Compound 4, half-maximal inhibitory concentration: 134 nM
Beside the measured number, compound 4's estimate is 1.1-fold (0.05 log units) above it, within the range that was stated.
By their numbers in this assay, from the lowest: compound 1; then compound 4; then compounds 3 and 2 (each within the scatter of the next).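

Compound 4 shows that the bromine alone does not hold the low number at this position. In this assay, 4-bromophenyl in place of 4-bromo-1H-pyrrol-2-yl on the carbonyl carbon gives an 8.4-fold higher number from compound 1 to compound 4 (0.92 log units; beyond the scatter), even though this change retains a bromine and swaps one aromatic ring for another. Yet 4-bromophenyl, which has no hydrogen-bond donor, also ranks ahead of both other replacements, with a 3.0-fold lower number from compound 3 to compound 4 (0.48 log units; beyond the scatter) and a 3.1-fold lower number from compound 2 to compound 4 (0.49 log units; beyond the scatter), so a replacement can recover part of the loss without a donor. No measurement accompanies these numbers that could account for any of these steps.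

Because the ring size, the ring nitrogen and its hydrogen-bond donor all change together between compound 1 and compound 4, the compounds shown leave open which of these differences accounts for the step. They also leave open what the bromine itself contributes on either ring, since none of them carries a hydrogen, a chlorine, an amine or a carboxylic acid in its place.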